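The compounds below may be only part of what the source reports. "The series", "measured", "known", "first", "only" and "open" are said of these compounds alone.

Of the compounds shown here, two have been measured in a functional assay on UACC-62 cells (Homo sapiens) for inhibition, read by sulforhodamine B assay, with a stated time of 48 h; on this read-out higher numbers stand for weaker inhibition and lower numbers for stronger inhibition. Compound 1 `O=C(Nc1cccc(-n2cc(-c3ccncc3)c(-c3cc(O)cc(Cl)c3)n2)c1)Nc1ccc(Cl)c(Cl)c1` gives 1690 nM in this assay, and compound 2 `COc1cc(Cl)cc(-c2nn(-c3cccc(NC(=O)Nc4ccc(Cl)c(C(F)(F)F)c4)c3)cc2-c2ccncc2)c1` gives 1270 nM. Compound 2 holds the lower of the two numbers, but the gap to compound 1 falls within the scatter of this kind of measurement, so the two values cannot be told apart. Compound 3 `COc1cc(Cl)cc(-c2nn(-c3cccc(NC(=O)Nc4ccc(Cl)c(Cl)c4)c3)cc2-c2ccncc2)c1` has not yet been measured. It differs from compound 2 in one place: chloro in place of trifluoromethyl on an aromatic carbon. For the measured compounds named here, no measured pair shows this exchange on its own, so its effect is unknown here. Compound 3 is therefore expected to land close to compound 2, with no step beyond the scatter in either direction, which means an expected step of a 1.1-fold higher number from compound 2 to compound 3 (0.04 log units; within the scatter). For compound 3 the estimate in this assay is 1400 nM, with a range from 600 nM to 3300 nM.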

Compound 3, half-maximal inhibitory concentration: 2400 nM
The estimate for compound 3 lay 1.7-fold (0.23 log units) below the measured number, within the range that was stated.
By their numbers in this assay, from the lowest: compounds 2, 1 and 3 (each within the scatter of the next).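

In this assay, for the compounds shown here, chloro in place of trifluoromethyl on this aromatic carbon, ortho to a chloro group, is now seen on its own for the first time and gives a 1.9-fold higher number from compound 2 to compound 3 (0.28 log units; within the scatter); at this position, the exchange from 4-chloro-3-(trifluoromethyl)phenyl to 3,4-dichlorophenyl therefore does not move the number beyond the scatter. The second exchange, methyl in place of hydrogen on the oxygen on an aromatic ring, gives a 1.4-fold higher number from compound 1 to compound 3 (0.15 log units; within the scatter) and also stays inside the scatter. No supporting measurement bears on why either step has the size it has.

Going by these compounds, it remains open how a nitrile or a methoxy group would read at the first position, and how an ethyl group or a longer chain on the oxygen would read at the second. Compounds 1 and 2 differ in two places, so they cannot show whether the two exchanges act independently of each other.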